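From urea to amide on a shared core

A few compounds are considered here, and "the series" means these few. Any claim that something is new, unique, unknown or untested is made for them only; others in the source may bear on it.

For the measured compounds named here, compound 2 `COc1cc(-c2nn(-c3cccc(NC(=O)Nc4cccc(C(F)(F)F)c4)c3)cc2-c2ccncc2)ccc1Cl` gives 3530 nM in a functional assay on NCI-H460 cells (Homo sapiens) for inhibition, read by sulforhodamine B assay, with a stated time of 48 h (a lower number here means a stronger inhibitor of growth, a higher number a weaker inhibitor of growth), the only number among the two values shown; compound 1 `COc1cc(-c2nn(-c3cccc(NC(=O)Nc4ccc(Cl)c(Cl)c4)c3)cc2-c2ccncc2)ccc1Cl` is its measured partner. In this assay compound 1 gives > 50000 nM, which is a limit of the assay and not a number (the limit of > 50000 nM in this assay, at which 1 of the 2 values shown sits). The step of an at least 14-fold lower number from compound 1 to compound 2 (1.15 log units; beyond the scatter) therefore rests on one bounded value. Compound 3 `COc1cc(-c2nn(-c3cccc(NC(=O)c4ccc(Cl)c(C(F)(F)F)c4)c3)cc2-c2ccncc2)ccc1Cl` carries 4-chloro-3-(trifluoromethyl)phenyl in place of (3-(trifluoromethyl)phenyl)amino on a carbonyl carbon. Going by the values given here, no measured step alters the carbonyl linkage itself, and the single measured step concerns a different aryl swap, so a wide range is expected. Compound 3 is estimated at 6000 nM, ranging from 1500 nM to 30000 nM. The expected step is a 1.7-fold higher number from compound 2 to compound 3 (0.23 log units; within the scatter).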

Compound 3, concentration for total growth inhibition: > 32500 nM
Compound 3 was reported as a limit; the forecaster's own chance of this, stated with the estimate: 20%; middle value at least 5.4-fold (0.73 log units) from the limit.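

Putting 4-chloro-3-(trifluoromethyl)phenyl in place of (3-(trifluoromethyl)phenyl)amino on the carbonyl carbon turns the urea into an amide and gives an at least 9.2-fold higher number from compound 2 to compound 3 (0.96 log units; beyond the scatter) in this assay, so this change at this position loses growth inhibition. Compound 3 is reported only as a limit of the assay: the limit of > 32500 nM in this assay, at which 1 of the 3 values shown sits.

Compound 1 and compound 3 are both limits, and the step between them cannot be read.

The compounds shown leave open whether the lost amino link or the added chlorine carries this step. They also leave open how an amide bearing a nitrile or a carboxylic acid on that ring would read.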